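Lengthening the Ring Substituent from Ethyl to Isobutyl

The compounds below may be only part of what the source reports. "The series", "measured", "known", "first", "only" and "open" are said of these compounds alone.

Compound 1 `O=C1Nc2ccccc2C1CCCCN1CCN(c2cccc(Cl)c2)CC1` and compound 2 `CCC1(CCCCN2CCN(c3cccc(Cl)c3)CC2)C(=O)Nc2ccccc21` share one core and differ in a single place. In a functional assay on the whole organism (strain Wistar) with Rattus norvegicus as the target, with a stated time of 5 min (a higher number here means that more compound is needed for the effect, a lower number that less compound is needed), compound 1 gives < 5 mg/kg, which is a limit of the assay. In this assay compound 2 gives > 20 mg/kg, again a limit rather than a number. Among the compounds with values here, the only measured step is an at least 4.0-fold higher number from compound 1 to compound 2 (0.60 log units; beyond the scatter). Compound 3 `CC(C)CC1(CCCCN2CCN(c3cccc(Cl)c3)CC2)C(=O)Nc2ccccc21` carries the change (isopropyl in place of methyl on a saturated chain carbon bound to a saturated ring carbon). Because ethyl in place of hydrogen already moved the reading to the limit of > 20 mg/kg in this assay, at which 1 of the 2 values shown sits, growth to isobutyl is expected to leave it at that limit or beyond. Compound 3 is therefore expected at 40 mg/kg, within 15 mg/kg to 150 mg/kg. The expected step is a step that the limit leaves unreadable from compound 2 to compound 3.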

Compound 3, minimum effective dose: 10 mg/kg
Compound 3: middle estimate off by 4.0-fold (0.60 log units), on the high side, outside the stated range (below it).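

In this assay, compound 3 gives a plain number where compound 1 and compound 2 gave only limits of the assay. Growth from ethyl to isobutyl on the saturated ring carbon did not raise the number further, giving an at least 2.0-fold lower number from compound 2 to compound 3 (0.30 log units; that floor lies within the scatter). Isobutyl in place of hydrogen gives an at least 2.0-fold higher number from compound 1 to compound 3 (0.30 log units; that floor lies within the scatter), and, as each step rests on a limit, neither floor alone shows a change beyond the scatter.

As far as these compounds go, the true size of both steps stays open. So does whether a longer chain or an amine on this ring carbon would read like ethyl or like isobutyl.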